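This account rests on a few compounds, and the source may have more. Where it says the series, first, only, none or still open, it means among the compounds named here.

Of the compounds shown here, three sharing one core have been measured in a functional assay for inhibition, with Homo sapiens as the target; on this read-out higher numbers stand for weaker inhibition and lower numbers for stronger inhibition. Compound 1 `Cc1cccc(Nc2nccc(-c3cc(C)oc3C)n2)c1` gives 28500 nM. Compound 2 `COc1cccc(Nc2nccc(-c3cc(C)oc3C)n2)c1` gives 5800 nM. Compound 3 `Cc1cc(-c2ccnc(Nc3ccccc3)n2)c(C)o1` gives 2000 nM. Among these numbers compound 2 stands second highest: its nearest neighbour is compound 3, reached by a 2.9-fold lower number from compound 2 to compound 3 (0.46 log units; beyond the scatter), and its furthest is compound 1, from which it is reached by a 4.9-fold lower number from compound 1 to compound 2 (0.69 log units; beyond the scatter). The third measured step, a 14-fold lower number from compound 1 to compound 3 (1.15 log units; beyond the scatter), likewise changes only the group on the outer ring of the core.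

Compound 4 `COc1cccc(Nc2nccc(-c3ccco3)n2)c1` differs from compound 2 elsewhere: furan-2-yl in place of 2,5-dimethylfuran-3-yl on an aromatic carbon. Going by the values given here, none of the three measured steps touches this part of the structure, so no measured step bears directly on the change. Among the compounds with values here, the three measured steps show only that changes on the other ring move this assay by modest to large amounts, which says nothing about the size or direction of a change on the five-membered ring. With no guide, the plainest expectation is a step from compound 2 to compound 4 of a 1.0-fold higher number from compound 2 to compound 4 (0.01 log units; within the scatter), within the scatter, while allowing that it may prove larger either way. Compound 4 is therefore estimated at 6000 nM, in a range from 1500 nM to 25000 nM.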

Compound 4, half-maximal inhibitory concentration: 400 nM
Beside the measured number, compound 4's estimate is 15-fold (1.18 log units) above it; the whole stated range lies above it.
By their numbers in this assay, from the lowest: compound 4; then compound 3; then compound 2; then compound 1.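

In this assay, the five-membered ring on the shared core proves to be a sensitive position: furan-2-yl in place of 2,5-dimethylfuran-3-yl gives a 15-fold lower number from compound 2 to compound 4 (1.16 log units; beyond the scatter). Going by these compounds alone, this is a large step, and it shows that the number responds strongly to this ring and not only to the outer ring, which was the only part changed in the earlier steps, such as a 14-fold lower number from compound 1 to compound 3 (1.15 log units; beyond the scatter). The two furan groups have the same counted features, each being a five-membered aromatic ring with one hetero atom, one hydrogen-bond acceptor and no net charge, so the step comes from a change that removes the methyl groups and moves the point of attachment at once.

Nothing available explains the size of this step or separates the part played by the methyl groups from that of the attachment point. Still open, on these data alone, is whether furan-2-yl lowers the number to a similar extent with the outer rings of compound 1 and compound 3, and how a 5-methylfuran-2-yl, furan-3-yl or thiophen-2-yl group would behave at this position.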